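Nitro in Place of Chloro Across Two Cores

The source may hold more compounds than are shown below. What is called first, only, known or untested is meant among the compounds shown, and "the series" means these compounds.

Measured compounds:
Compound 1 `Clc1cccc(Nc2nc3ncccc3n2Cc2ccccc2)c1`: in a functional assay on HCT-116 cells (Homo sapiens) for antiproliferative activity, read by MTT assay, with a stated time of 72 h (on this read-out higher numbers stand for weaker inhibition of growth and lower numbers for stronger inhibition of growth), compound 1 gives 36300 nM.
Compound 2 `O=[N+]([O-])c1cccc(Nc2nc3ncccc3n2Cc2ccccc2)c1`: in this assay compound 2 gives 41700 nM.
Compound 3 `Cn1nc(-c2ccnc(Nc3ccc(Cl)cc3)n2)c2ccccc21`: in this assay compound 3 gives 8730 nM.

Compounds 1 and 2 share one core; compound 3 is built on another, and the difference between the two cores is not broken down here. Compound 3 holds the lowest of the three numbers in this assay, and its values against compound 1 and against compound 2 each stand apart beyond the scatter; these pairs are not laid out as single steps.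

Within the first core, the change nitro in place of chloro on an aromatic carbon produced a 1.1-fold higher number from compound 1 to compound 2 (0.06 log units; within the scatter). Compound 4 `Cn1nc(-c2ccnc(Nc3ccc([N+](=O)[O-])cc3)n2)c2ccccc21` applies the same kind of change to compound 3: nitro in place of chloro on an aromatic carbon. The two changes are not the same: around the place, the group on compound 1 sits meta to a large group, whereas on compound 3 it sits para to a large group. For the measured compounds named here, the cores differ as well, so the single measured example carries over only loosely.

The step from compound 3 to compound 4 in this assay is expected to be small, a 1.1-fold higher number from compound 3 to compound 4 (0.04 log units; within the scatter), because a 1.1-fold higher number from compound 1 to compound 2 (0.06 log units; within the scatter) stayed within the scatter. Compound 4 is estimated at 9500 nM in this assay. The expected range for compound 4 runs from 4000 nM to 23000 nM, widened for the change of core and place.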

Compound 4, concentration for 50% growth inhibition: 8220 nM
Compound 4: the middle estimate sits 1.2-fold (0.06 log units) above what was measured, within the range that was stated.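

On the second core, nitro in place of chloro on an aromatic carbon, para to a large group, gives a small step in this assay, with a 1.1-fold lower number from compound 3 to compound 4 (0.03 log units; within the scatter). Set beside the step on the first core, this result gives no sign that the core alters the outcome of the change: the same change on two cores in this assay, a 1.1-fold higher number (0.06 log units; within the scatter) from compound 1 to compound 2 and a 1.1-fold lower number (0.03 log units; within the scatter) from compound 3 to compound 4, 1.2-fold (0.09 log units) apart, within the scatter of two such steps What this does not show is a general rule, since the series offers only two pairs, the place of the group differs along with the core, and the separate share of place and core cannot be read from them; the finding also rests on this one cell line and read-out.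

The compounds shown leave open whether a group other than chloro and nitro on this aromatic carbon, such as an amine, a carboxylic acid or a longer chain, would give a step beyond the scatter on either core. They also leave open whether the same exchange gives a similarly small step on the core of compound 1 with the group para to a large group, which would separate place from core.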